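A few compounds are considered here, and "the series" means these few. Any claim that something is new, unique, unknown or untested is made for them only; others in the source may bear on it.

The account opens with compound 1 `Cc1cn(COCCO)c(=O)[nH]c1=O`, tested in a functional assay on L1210 cells (Mus musculus) for inhibition; a lower number here means a stronger inhibitor, a higher number a weaker inhibitor. Compound 1 stands only at a limit of the assay, recorded as > 1000 ug/mL, so no number is known for it. Among the measured compounds shown here, the single piece of evidence on its standing is the limit of > 1000 ug/mL in this assay, at which 1 of the 2 values shown sits. A second member of the set, compound 2 `Nc1nc(=O)n(COCCO)cc1[N+](=O)[O-]`, differs from compound 1 in several places at once; in this assay compound 2 gives 374 ug/mL, a number rather than a limit. For the measured compounds named here, no step between compound 1 and compound 2 is recorded, so of that pair only what the two values show can be said.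

The compound that follows is compound 3 `O=c1[nH]c(=O)n(COCCO)cc1/C=C/Br`, not yet tested. It differs from compound 1 by 2-bromoethenyl in place of methyl on an aromatic carbon. Going by the values given here, because compound 1 sits only at the limit of > 1000 ug/mL in this assay, at which 1 of the 2 values shown sits, no measured step exists against which this change could be sized, and the reading for compound 3 is expected to stay near that limit, with any step from compound 1 not expected to go beyond the usual scatter. Compound 3 is thus expected to give about 800 ug/mL in this assay, within a range from 200 ug/mL to 3000 ug/mL. The estimated step of an at least 1.2-fold lower number from compound 1 to compound 3 (0.09 log units; that floor lies within the scatter) is accordingly expected to be small.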

Compound 3, concentration for 50% inhibition: > 1000 ug/mL
Compound 3 gave a limit, no number; the forecaster's own chance of this, stated with the estimate: 60%; middle value at least 1.2-fold (0.09 log units) from the limit.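

In this assay compound 3 gives > 1000 ug/mL, a limit and not a number. Among the compounds shown here, compound 1 also stands at a limit, so no step between compound 1 and compound 3 can be read: the limit of > 1000 ug/mL in this assay, at which 2 of the 3 values shown sit. The compounds shown leave open how much 2-bromoethenyl in place of methyl on an aromatic carbon changes inhibition.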